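Amide-piperidine series: quinolinyl to tetrahydronaphthyl swap at the amine

The source may report more compounds than this note shows. Statements on the series, on what has been measured and on what is new or still open speak of the compounds shown alone.

Three compounds have numbers in an assay on isolated protein for binding affinity to melanin-concentrating hormone receptor 1 (Homo sapiens); on this read-out lower numbers stand for stronger inhibition and higher numbers for weaker inhibition. Compound 1 `COc1cc(C(=O)NC2CCN(Cc3ccc4ccccc4c3)CC2)ccc1F` gives 13 nM in this assay, compound 2 `O=C(NC1CCN(Cc2ccc3ccccc3c2)CC1)c1ccc(Cl)cc1` gives 232 nM, and compound 3 `COc1cc(OC)cc(C(=O)NC2CCN(Cc3ccc4ccccc4n3)CC2)c1` gives 625 nM, the highest of the three numbers. For the measured compounds named here, the only single-point step measured is an 18-fold higher number from compound 1 to compound 2 (1.25 log units; beyond the scatter), which concerns the aryl group on the carbonyl carbon and leaves the amine substituent untouched. Compound 3 stands apart from compounds 1 and 2 in two places at once, the aryl amide and the group on the amine, so its gap to either of them cannot be split between the two changes.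

Compound 4 `COc1cc(OC)cc(C(=O)NC2CCN(CC3CCc4ccccc4C3)CC2)c1` differs from compound 3 by 1,2,3,4-tetrahydronaphthalen-2-yl in place of quinolin-2-yl on a saturated chain carbon bound to an amine nitrogen in a ring. Going by the values given here, no measured step in this assay isolates that position, and the only step recorded bears on a different part of the molecule. Among the compounds with values here, with no direct precedent, the expectation for this assay is a step of modest size or none beyond the scatter, with some lean toward a lower number given that compound 3 already sits at the top of the range. Compound 4 is therefore estimated at 300 nM, with a range from 80 nM to 1200 nM, corresponding to an expected step of a 2.1-fold lower number from compound 3 to compound 4 (0.32 log units; beyond the scatter).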

Compound 4, inhibition constant: 136 nM
Compound 4: the middle estimate sits 2.2-fold (0.34 log units) above what was measured, and the stated range covers the measured number.
By their numbers in this assay, from the lowest: compound 1; then compounds 4 and 2 (each within the scatter of the next); then compound 3.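

In this assay, for the compounds shown here, this is the first step that isolates the group on a saturated chain carbon bound to an amine nitrogen in a ring: with the aryl amide held constant, the change gives a 4.6-fold lower number from compound 3 to compound 4 (0.66 log units; beyond the scatter), so the read-out responds to this position as well as to the aryl group on the carbonyl carbon. The swap keeps the heavy-atom count unchanged but removes the ring nitrogen with its hydrogen-bond acceptor and turns one aromatic ring into a non-aromatic ring of carbon only, which shows that quinolin-2-yl is not required here for a lower number, while these two changes arrive together and cannot be told apart. Nothing available gives a measured basis for explaining this step.

A tetrahydroquinolinyl group at this place, with a ring nitrogen and a non-aromatic ring together, would help separate the two changes. Going by these compounds, it also remains open whether the step carries over to compounds with the 4-fluoro-3-methoxyphenyl group of compound 1 on the carbonyl carbon.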